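The compounds below may be only part of what the source reports. "The series", "measured", "known", "first", "only" and "open" are said of these compounds alone.

Measured so far:
Compound 1 `COC(=O)c1cc(=O)c2cc(NC(=O)Nc3ccc(Cl)c(C(F)(F)F)c3)ccc2[nH]1`: > 12600 nM (a limit)
Compound 2 `COC(=O)c1cc(=O)c2cc(NC(=O)Nc3ccc(Cl)c(Cl)c3)ccc2[nH]1`: 5520 nM

Within the data shown here, in a functional assay on SUP-B15 cells (Homo sapiens) for antiproliferative activity, with a stated time of 72 h (a lower number here means that less compound is needed, a higher number that more compound is needed for the effect), compound 2 gives 5520 nM, the only true number so far. Compound 1 stands at > 12600 nM, which is a limit of the assay and not a number. The next compound, compound 3 `COC(=O)c1cc(=O)c2cc(NC(=O)Nc3ccc4c(c3)CCC4)ccc2[nH]1`, keeps the shared core of compound 2 and carries 2,3-dihydro-1H-inden-5-yl in place of 3,4-dichlorophenyl on an amide-type nitrogen.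

Among the measured compounds shown here, only one measured step bears on this change, and it does so indirectly. It is an at least 2.2-fold lower number from compound 1 to compound 2 (0.35 log units; beyond the scatter), with chloro in place of trifluoromethyl on an aromatic carbon. That step shows that this assay responds to a change in this part of the molecule, but neither of its compounds carries the incoming group. It therefore gives no direction for the new change, and no step beyond the scatter is expected. The expected change is a 1.1-fold higher number from compound 2 to compound 3 (0.04 log units; within the scatter), an estimate with either direction left open. In this assay the estimate for compound 3 is 6000 nM, with an expected range from 2000 nM to 14000 nM.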

Compound 3, half-maximal effective concentration: > 24100 nM
Compound 3 was reported as a limit; the forecaster's own chance of this, stated with the estimate: 25%; middle value at least 4.0-fold (0.60 log units) from the limit.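

In this assay the change from 3,4-dichlorophenyl to 2,3-dihydro-1H-inden-5-yl on the amide-type nitrogen gives an at least 4.3-fold higher number from compound 2 to compound 3 (0.64 log units; beyond the scatter), so the incoming group moves the read-out beyond the scatter and in the direction of needing more compound. The earlier step had shown only that this part of the molecule matters, and it had given no direction for this group. Compound 3 is reported as > 24100 nM, which is a limit of the assay and not a number, so the step has a lower bound but no true size: the limit of > 24100 nM in this assay, at which 1 of the 3 values shown sits.

The compounds shown do not separate the departure of the two chlorine atoms from the entry of the five-membered non-aromatic ring, as both happen in the same step. They also leave open how this assay would respond to a plain phenyl group or a methoxyphenyl group on the same amide-type nitrogen, and whether any group there would give a lower number than compound 2, which stands at 5520 nM.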